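A few compounds are considered here, and "the series" means these few. Any claim that something is new, unique, unknown or untested is made for them only; others in the source may bear on it.

Measured compounds:
compound 1, `Brc1ccccc1CSc1nnc(-c2ccncc2)n1-c1ccccc1`: 17100 nM
compound 2, `O=C(CSc1nnc(-c2ccncc2)n1-c1ccccc1)N/N=C/c1ccc([N+](=O)[O-])cc1`: 15900 nM

Compound 1 and compound 2 share the core that carries the pyridinyl-triazole and the phenyl; both were run in a functional assay on HepG2 cells (Homo sapiens) for inhibition, read by MTT assay, with a stated time of 48 h (a higher number here means a weaker inhibitor, a lower number a stronger inhibitor), and compound 1 gives 17100 nM while compound 2 gives 15900 nM. Compound 2 has the lowest number of the two, but its nearest neighbour, compound 1, lies within the scatter, so no order between them can be read.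

Compound 3, `O=C(CSc1nnc(-c2ccncc2)n1-c1ccccc1)N/N=C/c1cc(Br)ccc1O`, has not yet been measured in this assay. It differs from compound 2 in one place: 5-bromo-2-hydroxyphenyl in place of 4-nitrophenyl on a carbon with a double bond to nitrogen. Going by the values given here, no step between measured compounds covers this kind of exchange, so there is nothing to size it by. With both measured numbers sitting close together and weak, the expectation is a small step in either direction, most likely none beyond the scatter.

Compound 3 is therefore expected to give about 12000 nM, with a range from 4000 nM to 40000 nM. The expected step of a 1.3-fold lower number from compound 2 to compound 3 (0.12 log units; within the scatter) is an estimate, not a measured figure.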

Compound 3, half-maximal inhibitory concentration: 4390 nM
For compound 3 the middle estimate is 2.7-fold (0.44 log units) above the measured one, and the stated range covers the measured number.
By their numbers in this assay, from the lowest: compound 3; then compounds 2 and 1 (each within the scatter of the next).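

Going by these compounds alone, the aryl group on a carbon with a double bond to nitrogen is the first place where a single exchange gives a readable step in this assay: 5-bromo-2-hydroxyphenyl in place of 4-nitrophenyl gives a modest change (a 3.6-fold lower number from compound 2 to compound 3 (0.56 log units; beyond the scatter)), beyond the scatter. Within the data shown here, compound 1 and compound 2 differ in more than one place and gave no such step, so this pair provides the first sign that the series responds to a change at this spot. The exchange removes the nitro group and brings in both a bromine and a hydroxyl, with one hydrogen-bond donor entering where the leaving group had none, and nothing shown explains the step.

On these data alone, whether the step belongs to the bromine, to the hydroxyl or to the loss of the nitro group remains open, as a single pair cannot separate these three changes. Also open, as far as these compounds go, is how the number in this assay would respond to an amine or a carboxylic acid on this phenyl, or to a longer chain in place of the ring.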